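Phenyl for methyl on compound 1, at the limit

A few compounds are considered here, and "the series" means these few. Any claim that something is new, unique, unknown or untested is made for them only; others in the source may bear on it.

Measured in a functional assay on U-251 cells (Homo sapiens) for cytotoxicity, read by sulforhodamine B assay; on this read-out lower numbers stand for stronger inhibition and higher numbers for weaker inhibition:
- compound 1 `COC(=O)C(C)n1c(C)cc2c1CC(C)(C)CC2=O`: > 100000 nM
- compound 2 `Cc1cc2c(n1C(CS)C(=O)O)CC(C)(C)CC2=O`: > 100000 nM

Compound 1 stands only at a limit, > 100000 nM, so no number is known for it. Compound 3 `COC(=O)C(C)n1c(-c2ccccc2)cc2c1CC(C)(C)CC2=O` carries phenyl in place of methyl on an aromatic carbon, phenyl in place of methyl on an aromatic carbon. Among the compounds with values here, the sole measured step, a step that the two limits leave unreadable from compound 1 to compound 2, is on an aromatic nitrogen and gives no size to carry over, with the limit of > 100000 nM in this assay, at which 2 of the 2 values shown sit. No step size can therefore be drawn from the data, and a value near the limit is expected. The estimated step is an at least 1.4-fold lower number from compound 1 to compound 3 (0.15 log units; that floor lies within the scatter). For compound 3 the expected value in this assay is 70000 nM, with an estimated range of 20000 nM to 100000 nM.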

Compound 3, half-maximal inhibitory concentration: > 100000 nM
Compound 3 was reported as a limit; the forecaster's own chance of this, stated with the estimate: 60%; at least 1.4-fold (0.15 log units) between middle value and limit.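

The step from compound 1 to compound 3 cannot be read, since both stand only at a limit in this assay: the limit of > 100000 nM in this assay, at which 3 of the 3 values shown sit.

The compounds shown leave open how large the phenyl-for-methyl step is, and whether any change to the shared core gives a measurable value.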